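Trimethoxyphenyl in Place of Fluorophenyl on a Shared Core

This account rests on a few compounds, and the source may have more. Where it says the series, first, only, none or still open, it means among the compounds named here.

Of the compounds shown here, two sharing one core have been measured in a functional assay on PC-3 cells (Homo sapiens) for inhibition, read by MTT assay, with a stated time of 72 h; a higher number here means a weaker inhibitor, a lower number a stronger inhibitor. Compound 1 `CCc1ccc(NC(=O)CSc2nc(Nc3ccccc3)c3ccccc3n2)cc1` gives 17900 nM in this assay. Compound 2 `C=CC(=O)Nc1cccc(NC(=O)CSc2nc(Nc3ccccc3F)c3ccccc3n2)c1` gives 9340 nM in this assay; this is the lowest of the two numbers, yet its gap to compound 1 lies within the scatter, so the two cannot be ranked against each other. Compound 3 `C=CC(=O)Nc1cccc(NC(=O)CSc2nc(Nc3cc(OC)c(OC)c(OC)c3)c3ccccc3n2)c1` has not yet been measured. It differs from compound 2 in a single place: 3,4,5-trimethoxyphenyl in place of 2-fluorophenyl on a nitrogen on an aromatic ring. For the measured compounds named here, no step between measured compounds that differ in one place is available as a guide, so only the structural change itself can be weighed. For compound 3 a modest move toward a lower number is expected, a step of a 2.3-fold lower number from compound 2 to compound 3 (0.37 log units; beyond the scatter) that may or may not exceed the scatter. Compound 3 is therefore estimated at 4000 nM, with a range from 1000 nM to 15000 nM.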

Compound 3, half-maximal inhibitory concentration: > 50000 nM
Compound 3: no number, only a limit; the forecaster's own chance of this, stated with the estimate: 5%; at least 12-fold (1.09 log units) between middle value and limit.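

In this assay compound 3 gives > 50000 nM, which is a limit of the assay and not a number. For the compounds shown here, putting 3,4,5-trimethoxyphenyl in place of 2-fluorophenyl on this nitrogen gives an at least 5.3-fold higher number from compound 2 to compound 3 (0.72 log units; beyond the scatter), the first readable step, and it shows that the group at this position can by itself move the number beyond the scatter. The full size of the step cannot be read, since only a bound on it is available: the limit of > 50000 nM in this assay, at which 1 of the 3 values shown sits.

On these data alone, it remains open whether the number rises with the loss of the fluorine or with the arrival of the methoxy groups. A phenyl carrying a single methoxy group, or a chlorophenyl, on this nitrogen would be needed to separate the two, and compound 1 differs from compound 2 in more than one place, so it cannot settle this.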